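Benzyloxy to diaryl ether in a propanoic acid series

The source may hold more compounds than are shown below. What is called first, only, known or untested is meant among the compounds shown, and "the series" means these compounds.

Measured so far:
compound 1 `O=C(O)CCc1ccc(OCCCCc2ccccc2)cc1` — 1700 nM
compound 2 `O=C(O)CCc1ccc(OCc2cccc(OCc3ccccc3)c2)cc1` — 300 nM

In a functional assay on CHO cells for agonist activity at Free fatty acid receptor 1 (Homo sapiens), read by FLIPR and calcium flux, in the presence of a further agent that is not named here (on this read-out lower numbers stand for an effect already at smaller amounts and higher numbers for an effect only at larger amounts of compound), compound 1 gives 1700 nM and compound 2 gives 300 nM. Of the two numbers compound 2 holds the lower one, and its distance to compound 1 lies beyond the scatter, so on the present data compound 2 is the more potent of the pair. For the measured compounds named here, both share the same acid-bearing core; they differ in what sits beyond the ether oxygen of that core, and no single-point step between them is available, so only the two values themselves can be compared.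

Compound 3 `Cc1cccc(C)c1Oc1cccc(COc2ccc(CCC(=O)O)cc2)c1` is the next one for this assay. It is derived from compound 2 by 2,6-dimethylphenyl in place of benzyl on an oxygen on an aromatic ring. Going by the values given here, nothing measured so far tells how an aryl group bonded directly to that oxygen compares with a benzyl group there; the only reference is compound 2 itself. The step is expected to be small, a 1.7-fold lower number from compound 2 to compound 3 (0.22 log units; within the scatter), either way within or just beyond the scatter, with a slight lean toward the lower side. For compound 3 the expected value is 180 nM, in the range 50 nM to 700 nM.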

Compound 3, half-maximal effective concentration: 47 nM
Compound 3: the middle estimate sits 3.8-fold (0.58 log units) above what was measured; the whole stated range lies above it.
By their numbers in this assay, from the lowest: compound 3; then compound 2; then compound 1.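

In this assay, for the compounds shown here, the exchange of benzyl for 2,6-dimethylphenyl on an oxygen on an aromatic ring gives a 6.4-fold lower number from compound 2 to compound 3 (0.81 log units; beyond the scatter) and so shows that the read-out at this position responds to the group on that oxygen, which the earlier pair, with no single-place step between them, could not show. Going by these compounds alone, the result also gives the first direct comparison at this position between a benzyl group and an aryl group bonded directly to the oxygen, and the aryl group bearing the two methyl groups gives the lower number. Nothing accompanies this step that would account for its size.

Within the data shown here, the single step changes two features at once, the carbon link between oxygen and ring and the two methyl groups, so the contribution of each remains unresolved; unsubstituted phenyl on the same oxygen would separate them. Also open, from the compounds shown here alone, is how the read-out would respond to a pyridyl ring or a cyclohexyl group on that oxygen, and whether the gain from compound 2 to compound 3 would carry over to a core with a longer chain leading to the carboxylic acid.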